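The compounds below may be only part of what the source reports. "The series", "measured", "known", "first", "only" and "open" are said of these compounds alone.

Measured in a functional assay on HCT-116 cells (Homo sapiens) for antiproliferative activity, read by sulforhodamine B assay, with a stated time of 48 h (a higher number here means a weaker inhibitor, a lower number a stronger inhibitor), so far:
- compound 1 `COc1cc(O)c(C(=O)/C=C/c2ccc(OC)c(OC)c2)c(OC)c1` gives 27600 nM
- compound 2 `COc1cc(O)c(C(=O)/C=C/c2ccc(F)cc2)c(OC)c1` gives 4400 nM

Of these two numbers, compound 2 holds the lower, and the gap to compound 1 lies beyond the scatter. Compound 3 `COc1cc(O)c(C(=O)/C=C/c2ccc(Br)cc2)c(OC)c1` is not yet measured in this assay and differs from compound 2 in one place, with bromo in place of fluoro on an aromatic carbon, para to a large group bromo in place of fluoro on an aromatic carbon (4-fluorophenyl to 4-bromophenyl). For the measured compounds named here, no measured pair differs in one place only, so the data offer no direct guide to this change. The expectation rests on compound 2 at 4400 nM alone. The expected step of a 1.1-fold lower number from compound 2 to compound 3 (0.04 log units; within the scatter) is small, within the scatter and without a firm direction. The estimated value for compound 3 is 4000 nM (expected range 1500 nM to 11000 nM).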

Compound 3, half-maximal inhibitory concentration: 14000 nM
Estimate against measurement, compound 3: 3.5-fold (0.54 log units) below, outside the stated range (above it).
By their numbers in this assay, from the lowest: compound 2; then compounds 3 and 1 (each within the scatter of the next).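

For the compounds shown here, the change from 4-fluorophenyl to 4-bromophenyl is the only one-place comparison so far, and in this assay it reads as a 3.2-fold higher number from compound 2 to compound 3 (0.50 log units; beyond the scatter). This position, on an aromatic carbon and para to a large group, is therefore not indifferent to which halogen it carries, and fluoro gives the lower number of the two. No supporting data bear on why this step occurs.

As far as these compounds go, only fluoro and bromo have been compared at this position, so it remains open where chloro or the unsubstituted phenyl would fall and whether the numbers follow any order across the halogens. From the compounds shown here alone, how an amine or a carboxylic acid would read at the same carbon also remains open.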